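The compounds below may be only part of what the source reports. "The series", "measured", "known", "first", "only" and "open" are said of these compounds alone.

Three thiourea compounds built on one shared core have been measured in a functional assay on HepG2 cells (Homo sapiens) for antiproliferative activity, read by MTT assay; on this read-out higher numbers stand for weaker inhibition and lower numbers for stronger inhibition. Compound 1 `CNC(=O)c1ccc(Oc2cccc(NC(=S)Nc3cc(C(F)(F)F)cc(C(F)(F)F)c3)c2)nc1` gives 4550 nM. Compound 2 `CNC(=O)c1ccc(Oc2cccc(NC(=S)Nc3ccc(F)c(C(F)(F)F)c3)c2)nc1` gives 20200 nM. Compound 3 `CNC(=O)c1ccc(Oc2cccc(NC(=S)Nc3cccc(C(F)(F)F)c3)c2)nc1` gives 23300 nM, the highest of the three numbers; compound 2 sits close to it, while compound 1 is farther off, as the step of a 5.1-fold higher number from compound 1 to compound 3 (0.71 log units; beyond the scatter) shows.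

The next compound, compound 4 `CNC(=O)c1ccc(Oc2cccc(NC(=S)Nc3ccc(Cl)c(C(F)(F)F)c3)c2)nc1`, differs from compound 3 in one place: chloro in place of hydrogen on an aromatic carbon. The measured step that speaks most directly to this change is a 1.2-fold higher number from compound 2 to compound 3 (0.06 log units; within the scatter), where a halogen at the same kind of position came and went without a shift beyond the scatter. Within the data shown here, the only step that moved the number clearly, a 5.1-fold higher number from compound 1 to compound 3 (0.71 log units; beyond the scatter), concerns a trifluoromethyl group elsewhere on the ring, so it is a looser guide.

Taken together, the expectation for compound 4 is a small gain at most, leaning toward a somewhat lower number than compound 3 because the one clearly active change, a 5.1-fold higher number from compound 1 to compound 3 (0.71 log units; beyond the scatter), went that way when a group was added to that ring. The expected step is a 2.1-fold lower number from compound 3 to compound 4 (0.33 log units; beyond the scatter), and compound 4 is therefore estimated at 11000 nM, with a likely range from 4500 nM to 26000 nM.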

Compound 4, half-maximal inhibitory concentration: 5350 nM
Beside the measured number, compound 4's estimate is 2.1-fold (0.31 log units) above it; low and high end bracket the measured number.
By their numbers in this assay, from the lowest: compounds 1 and 4 (each within the scatter of the next); then compounds 2 and 3 (each within the scatter of the next).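

In this assay, the place ortho to a trifluoromethyl group and para to a large group proves responsive to substitution, since putting chloro there in place of hydrogen gives a 4.4-fold lower number from compound 3 to compound 4 (0.64 log units; beyond the scatter) on this ring. The earlier fluoro compound could not show this, as its step, a 1.2-fold higher number from compound 2 to compound 3 (0.06 log units; within the scatter), stayed within the scatter, while the direct exchange of fluoro for chloro at the same place gives a 3.8-fold lower number from compound 2 to compound 4 (0.58 log units; beyond the scatter), so among these compounds the result depends on which halogen sits there and not simply on a halogen being present. Nothing available explains why chloro and fluoro part ways here.

From the compounds shown here alone, with only hydrogen, fluoro and chloro compared at this place, it remains open whether the lower number is particular to chloro or would also appear with bromo, methyl or methoxy. Going by these compounds, it is also open whether an amine or a carboxylic acid would be accepted at the same place, and whether the chloro gain would hold on a ring carrying a different partner in place of the trifluoromethyl group.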